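The source may hold more compounds than are shown below. What is called first, only, known or untested is meant among the compounds shown, and "the series" means these compounds.

Measured compounds:
compound 1 `O=C1c2ccc(C#Cc3cccs3)nc2CCN1C1CCCC1` with 12 nM
compound 2 `Cc1ccccc1C#Cc1ccc2c(n1)CCN(C1CCCCC1)C2=O` with 466 nM

In a functional assay on HEK293 cells for positive allosteric modulation of metabotropic glutamate receptor 5 (Homo sapiens), read by FLIPR and calcium flux (on this read-out higher numbers stand for an effect only at larger amounts of compound and lower numbers for an effect already at smaller amounts), compound 2 gives 466 nM, the higher of the two numbers; compound 1 gives 12 nM, a gap that lies well beyond the usual scatter. Compound 3 `O=C1c2ccc(C#Cc3cccnc3)nc2CCN1C1CCCCC1` has not yet been measured. It differs from compound 2 in one place: pyridin-3-yl in place of 2-methylphenyl on a triple-bonded carbon. Among the compounds with values here, no measured pair in this set isolates such a change, so the expectation for compound 3 rests on the two numbers alone and on the nature of the swap. Compound 2 holds the highest value seen here, and the step to compound 3 is expected to move toward a lower number, most likely by a moderate amount: a 5.2-fold lower number from compound 2 to compound 3 (0.71 log units; beyond the scatter). On that basis compound 3 is estimated at 90 nM in this assay, with a range from 15 nM to 500 nM.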

Compound 3, half-maximal effective concentration: 387 nM
Beside the measured number, compound 3's estimate is 4.3-fold (0.63 log units) below it; the measured number falls inside the stated range.
By their numbers in this assay, from the lowest: compound 1; then compounds 3 and 2 (each within the scatter of the next).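

In this assay, within the data shown here, pyridin-3-yl in place of 2-methylphenyl on a triple-bonded carbon gives a 1.2-fold lower number from compound 2 to compound 3 (0.08 log units; within the scatter), the first direct reading of a change at this position. Exchanging a ring of carbon only for one with a hetero atom, which also brings in a hydrogen-bond acceptor, therefore does not separate these two compounds on this read-out. Nothing available accounts for this result.

Compound 3 differs from compound 1 in more than one place, so the compounds shown do not assign the value of compound 1, 12 nM, to any single place. Also open, on these data alone, is how unsubstituted phenyl, pyridin-2-yl or pyridin-4-yl would read on the same triple-bonded carbon, with the rest of compound 3 unchanged.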